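This account rests on a few compounds, and the source may have more. Where it says the series, first, only, none or still open, it means among the compounds named here.

Within the data shown here, compound 2 `COc1cccc(NC(=O)/C=C/c2coc3cc(OC)ccc3c2=O)c1` is one of two compounds measured in an ADME assay on HepG2 2.2.15 cells (Homo sapiens) for cytotoxicity, read by MTT assay, with stated times of 48 h and 9 days (on this read-out lower numbers stand for higher toxicity in this test and higher numbers for lower toxicity in this test), where compound 2 gives 1130000 nM. Among the measured compounds shown here, its companion, compound 1 `COc1ccc2c(=O)c(/C=C/C(=O)Nc3cccc(Cl)c3)coc2c1`, gives 1100000 nM in this assay, and the two numbers lie within the usual scatter of each other, so neither can be told apart from the other; the one step between them, a 1.0-fold higher number from compound 1 to compound 2 (0.01 log units; within the scatter), swaps a group on an aromatic carbon and changes nothing that can be seen.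

Compound 3 `COc1ccc2c(=O)c(/C=C/C(=O)NCc3ccc(C)cc3)coc2c1` is not yet measured. It differs from compound 2 by 4-methylbenzyl in place of 3-methoxyphenyl on an amide-type nitrogen. For the measured compounds named here, no measured step touches the amide-type nitrogen, so nothing in the data speaks directly to this change; the only step available is the one on the aromatic carbon, which stayed within the scatter. Compound 3 is therefore expected to sit close to compound 2, with a step of a 1.1-fold lower number from compound 2 to compound 3 (0.05 log units; within the scatter) or none beyond the scatter, and the estimate for compound 3 in this assay is 1000000 nM, between 400000 nM and 2500000 nM.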

Compound 3, half-maximal cytotoxic concentration: 257000 nM
Estimate against measurement, compound 3: 3.9-fold (0.59 log units) above, outside the stated range (below it).
By their numbers in this assay, from the lowest: compound 3; then compounds 1 and 2 (each within the scatter of the next).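

The amide-type nitrogen proves to be a position that matters in this assay: 4-methylbenzyl in place of 3-methoxyphenyl gives a clear drop (a 4.4-fold lower number from compound 2 to compound 3 (0.64 log units; beyond the scatter)), and 4-methylbenzyl in place of 3-chlorophenyl gives a drop of much the same size (a 4.3-fold lower number from compound 1 to compound 3 (0.63 log units; beyond the scatter)). Unlike the swap on the aromatic carbon, this change moves the number beyond the scatter, toward higher toxicity in this test, and it does so from both earlier compounds. Nothing available explains the shift, so it stands as an observation only.

The new group differs from the old ones in two ways at once, a carbon link to the ring and a methyl group on it, and these compounds cannot separate the two. Going by these compounds, how a plain benzyl group or a longer chain such as 2-phenylethyl would behave on this nitrogen remains open.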